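Adding a second amine to the benzylamine side chain

The source may report more compounds than this note shows. Statements on the series, on what has been measured and on what is new or still open speak of the compounds shown alone.

Measured so far in a functional assay on U-87MG ATCC cells (Homo sapiens) for cytotoxicity, read by MTT assay, with a stated time of 72 h; a lower number here means a stronger inhibitor, a higher number a weaker inhibitor:
compound 1 `COc1ncc(-c2ccc3nccc(N4CCCC4)c3c2)cc1NS(=O)(=O)c1ccc(F)cc1F` — 6690 nM
compound 2 `CCN(CC)Cc1ccc(-c2ccnc3ccc(-c4cnc(OC)c(NS(=O)(=O)c5ccc(F)cc5F)c4)cc23)cc1` — 4890 nM
compound 3 `CCN(Cc1ccc(-c2ccnc3ccc(-c4cnc(OC)c(NS(=O)(=O)c5ccc(F)cc5F)c4)cc23)cc1)C1CCCCC1` — 1450 nM

Compound 2 stands second highest of the three numbers in this assay; its nearest neighbour is compound 1, with a 1.4-fold lower number from compound 1 to compound 2 (0.14 log units; within the scatter), and its furthest is compound 3, with a 3.4-fold lower number from compound 2 to compound 3 (0.53 log units; beyond the scatter). Compound 4 `CNCCN(C)Cc1ccc(-c2ccnc3ccc(-c4cnc(OC)c(NS(=O)(=O)c5ccc(F)cc5F)c4)cc23)cc1` has not yet been measured in this assay. Its change from compound 2 is methyl(2-(methylamino)ethyl)amino in place of diethylamino on a saturated chain carbon bound to an aromatic carbon.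

Among the measured compounds shown here, only one measured step touches the same part of the molecule: a 3.4-fold lower number from compound 2 to compound 3 (0.53 log units; beyond the scatter), where cyclohexyl replaced ethyl on the amine nitrogen and the number fell modestly. For the measured compounds named here, compound 4 instead replaces the whole diethylamino group with a chain carrying a second nitrogen, a change with no measured counterpart here. Because of a 3.4-fold lower number from compound 2 to compound 3 (0.53 log units; beyond the scatter) the site tolerates variation, but the direction for compound 4 cannot be read from the data. For compound 4 the expectation in this assay is 4000 nM, within 1500 nM to 11000 nM, an estimated step of a 1.2-fold lower number from compound 2 to compound 4 (0.09 log units; within the scatter) that is expected to lie within the scatter.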

Compound 4, half-maximal inhibitory concentration: 254 nM
Estimate against measurement, compound 4: 16-fold (1.20 log units) above, and the stated range ends above it.
By their numbers in this assay, from the lowest: compound 4; then compound 3; then compounds 2 and 1 (each within the scatter of the next).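

Among the compounds shown here, at this position the side chain proved far more sensitive than the earlier compounds suggested: in this assay, methyl(2-(methylamino)ethyl)amino in place of diethylamino gives a 19-fold lower number from compound 2 to compound 4 (1.28 log units; beyond the scatter) and so moves the number much further than the cyclohexyl exchange did (a 3.4-fold lower number from compound 2 to compound 3 (0.53 log units; beyond the scatter)). The same group also outdoes the cyclohexyl(ethyl)amino group of the earlier best compound (a 5.7-fold lower number from compound 3 to compound 4 (0.76 log units; beyond the scatter)), which shows that a chain bearing a second nitrogen and a hydrogen-bond donor is accepted here and goes with the lowest number in the set. Nothing measured here assigns this gain to any one feature of the entering group.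

On these data alone, it remains open whether the hydrogen on the terminal methylamino nitrogen matters, which a terminal dimethylamino group would test. Also open, as far as these compounds go, is whether a longer chain linking the two nitrogens, or a piperazine ring holding them, would keep the number this low.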